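Removing the methylsulfonyl group from compound 1

The source may hold more compounds than are shown below. What is called first, only, known or untested is meant among the compounds shown, and "the series" means these compounds.

Compound 1 `CS(=O)(=O)c1ccc(-c2cnc3[nH]cc(-c4nnc(-c5ccc(Cl)cc5)o4)c(=O)c3c2)cc1` and compound 2 `CS(=O)(=O)c1ccc(-c2cnc3[nH]cc(-c4nnc(-c5cccnc5)o4)c(=O)c3c2)cc1` share one core and differ only in pyridin-3-yl in place of 4-chlorophenyl on an aromatic carbon. In a functional assay on HCT-116 cells (Homo sapiens) for inhibition, read by MTT assay, with a stated time of 24 h, tested at 2.5 uM (a lower number here means less inhibition of growth, a higher number more inhibition of growth at the concentration tested), compound 1 gives 2.06%, and compound 2 gives 4.32%. The step of a number 2.3 percentage points higher from compound 1 to compound 2 (within the scatter) lies within the scatter, so the two compounds cannot be told apart. For the measured compounds named here, of the two numbers, that of compound 1 is the smaller, but the gap does not support any ordering; compound 2 is its only neighbour.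

Compound 3 `O=c1c(-c2nnc(-c3ccc(Cl)cc3)o2)c[nH]c2ncc(-c3ccccc3)cc12` has not yet been measured. It differs from compound 1 by hydrogen in place of methylsulfonyl on an aromatic carbon; cut one bond further out, the difference reads 4-(methylsulfonyl)phenyl to phenyl. Going by the values given here, no measured step touches this group: the one known step concerns the other end of the molecule and was small. Nothing in the two measured compounds therefore points away from their low values. The expected step is a number 2.9 percentage points higher from compound 1 to compound 3 (within the scatter), nothing beyond the scatter. The estimate for compound 3 in this assay is 5%, with a range from 0% to 18%.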

Compound 3, percent growth inhibition at one concentration: 9.81%
Beside the measured number, compound 3's estimate is 4.8 percentage points below it; measured number inside the range.
By their numbers in this assay, from the lowest: compounds 1, 2 and 3 (each within the scatter of the next).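

In this assay, hydrogen in place of methylsulfonyl on the aromatic carbon para to a large group gives a number 7.8 percentage points higher from compound 1 to compound 3 (within the scatter). For the compounds shown here, this is the first measured change at this end of the molecule, and it shows that the whole methylsulfonyl group can leave this position without a difference that can be told apart from the scatter, so compound 1 and compound 3 cannot be ranked against each other, and the group cannot be said to matter for growth inhibition at the concentration tested. No measurement shown here bears on why the two compounds read as they do.

The compounds shown leave open whether any group on this carbon can move the number beyond the scatter, for instance an amine or a carboxylic acid on the same phenyl ring in place of hydrogen. They also leave open whether pyridin-3-yl in place of 4-chlorophenyl would stay as small a step on the core of compound 3, which carries a plain phenyl, as it was with methylsulfonyl present.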